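The source may report more compounds than this note shows. Statements on the series, on what has been measured and on what is new or still open speak of the compounds shown alone.

The measured compounds:
Compound 1, `O=C(COc1cc(=O)oc2cc(OCc3cccc(Cl)c3)ccc12)N1CCCCC1`, gives 38900 nM in an assay on isolated protein (strain Sprague-Dawley) for inhibition of Amine oxidase [flavin-containing] B (Rattus norvegicus), read by spectrophotometry, with a stated time of 5 min; on this read-out higher numbers stand for weaker inhibition and lower numbers for stronger inhibition.
Compound 2, `Nc1cc(=O)oc2cc(OCc3cccc(Cl)c3)ccc12`, gives 47.9 nM in this assay.
Compound 3, `O=c1cc(CCl)c2ccc(OCc3cccc(Cl)c3)cc2o1`, gives 43.7 nM in this assay.

Compound 3 holds the lowest number of the three, though its nearest neighbour, compound 2, lies within the scatter of it, the step being a 1.1-fold lower number from compound 2 to compound 3 (0.04 log units; within the scatter). The distance to compound 1 is large: an 890-fold lower number from compound 1 to compound 3 (2.95 log units; beyond the scatter), matched by an 810-fold lower number from compound 1 to compound 2 (2.91 log units; beyond the scatter). Compound 4, `NC(=O)c1cc(=O)oc2cc(OCc3cccc(Cl)c3)ccc12`, has not been measured. It differs from compound 3 in one place: carbamoyl in place of chloromethyl on an aromatic carbon. Among the measured compounds shown here, two measured steps concern this place. Replacing the ((piperidin-1-yl)carbonyl)methoxy group by chloromethyl gave an 890-fold lower number from compound 1 to compound 3 (2.95 log units; beyond the scatter), while exchanging amino for chloromethyl gave a 1.1-fold lower number from compound 2 to compound 3 (0.04 log units; within the scatter). Since amino and chloromethyl sit within the scatter of each other here, a third group of comparable count is expected to fall in the same region. Compound 4 is therefore expected to show a 2.1-fold higher number from compound 3 to compound 4 (0.31 log units; beyond the scatter) in this assay, not beyond the scatter. Compound 4 is estimated at 90 nM, between 20 nM and 500 nM.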

Compound 4, half-maximal inhibitory concentration: 234 nM
Compound 4: middle estimate off by 2.6-fold (0.41 log units), on the low side; low and high end bracket the measured number.
By their numbers in this assay, from the lowest: compounds 3 and 2 (each within the scatter of the next); then compound 4; then compound 1.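

In this assay, the position opposite the ring oxygen proves sensitive to the choice among small groups: carbamoyl in place of chloromethyl gives a 5.4-fold higher number from compound 3 to compound 4 (0.73 log units; beyond the scatter), and carbamoyl in place of amino gives a 4.9-fold higher number from compound 2 to compound 4 (0.69 log units; beyond the scatter), a separation that amino and chloromethyl, within the scatter of each other, had not shown. Carbamoyl nevertheless remains well apart from the ((piperidin-1-yl)carbonyl)methoxy group, at a 170-fold lower number from compound 1 to compound 4 (2.22 log units; beyond the scatter), so the series now has an intermediate level rather than only two. Nothing available here accounts for these differences.

The compounds shown do not tell whether the step to compound 4 goes with the carbonyl or with the amide hydrogen, which a methyl ketone or a methyl ester would separate. Going by these compounds, a carboxylic acid and a methylcarbamoyl group at this position also remain open, as does a piperidin-1-ylcarbonyl group without the ether oxygen of compound 1.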